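Changing the fluorophenyl on the sulfonyl sulfur: clearance expectation

A few compounds are considered here, and "the series" means these few. Any claim that something is new, unique, unknown or untested is made for them only; others in the source may bear on it.

compound 1 `COc1ccc(-c2c(S(=O)(=O)c3cc(Cl)cc(Cl)c3)cnc3c(F)cccc23)cc1`: 2.11 mL/min
compound 2 `O=S(=O)(c1cccc(F)c1)c1cnc2c(F)cccc2c1-c1ccccc1F`: 0.21 mL/min
compound 3 `COc1ccc(-c2c(S(=O)(=O)c3ccc(F)cc3)cnc3c(F)cccc23)cc1`: 2.41 mL/min

In an ADME assay on microsomes from liver (Homo sapiens) for metabolic stability, tested at 2.5 uM (on this read-out higher numbers stand for fast clearance and lower numbers for slow clearance), compound 3 gives the highest of the three numbers, though compound 1 sits within the scatter of it. Going by the values given here, compound 2, at 0.21 mL/min, gives a clearly lower number, but it differs from compound 3 in more than one place, so no single step can be drawn from it. Compound 4 `COc1ccc(-c2c(S(=O)(=O)c3cccc(F)c3)cnc3c(F)cccc23)cc1` differs from compound 3 in one place: 3-fluorophenyl in place of 4-fluorophenyl on a sulfonyl sulfur. Among the compounds with values here, the one measured step at this position, a 1.1-fold higher number from compound 1 to compound 3 (0.06 log units; within the scatter), stayed within the scatter even though it exchanged a 3,5-dichlorophenyl for a 4-fluorophenyl. Compound 4 is therefore expected to give about 2.4 mL/min, between 1.2 mL/min and 4.8 mL/min. The step this estimate means, a 1.0-fold lower number from compound 3 to compound 4 (0.00 log units; within the scatter), is expected to stay within the scatter.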

Compound 4, intrinsic clearance in a liver preparation (reported as CLH), per the amount of preparation that the assay uses: 2.48 mL/min
Estimate against measurement, compound 4: 1.0-fold (0.01 log units) below, and the stated range covers the measured number.
By their numbers in this assay, from the lowest: compound 2; then compounds 1, 3 and 4 (each within the scatter of the next).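

In this assay the exchange of 4-fluorophenyl for 3-fluorophenyl on the sulfonyl sulfur gives a 1.0-fold higher number from compound 3 to compound 4 (0.01 log units; within the scatter) and the exchange of 3,5-dichlorophenyl for 3-fluorophenyl gives a 1.2-fold higher number from compound 1 to compound 4 (0.07 log units; within the scatter) so all three aryl groups at this position stand within the scatter of one another. Compound 4 also links compound 2 to the series in one place, on an aromatic carbon, where 4-methoxyphenyl in place of 2-fluorophenyl gives a 12-fold higher number from compound 2 to compound 4 (1.07 log units; beyond the scatter) and this is where the large step lies. The compounds shown leave open whether an amine or a carboxylic acid on the sulfonyl sulfur's aryl group would also leave the number in place. Nothing at hand explains the large step.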